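The source may hold more compounds than are shown below. What is called first, only, known or untested is meant among the compounds shown, and "the series" means these compounds.

Compound 3 `Cc1ccc(-c2ccc(C)n2-c2ccc(-c3nc4ccc(F)cc4s3)cc2)cc1` gives 2150 nM in a functional assay on MCF7 cells (Homo sapiens) for cytotoxicity, read by sulforhodamine B assay, with a stated time of 48 h; on this read-out higher numbers stand for weaker inhibition of growth and lower numbers for stronger inhibition of growth. The two other measured compounds, compound 1 `Cc1ccc(-c2ccc(C)n2-c2ccc(-c3nc4ccccc4s3)cc2)cc1` with 2500 nM and compound 2 `Cc1ccc(-c2ccc([N+](=O)[O-])cc2)n1-c1ccc(-c2nc3ccccc3s2)cc1` with 2540 nM, lie within the scatter of compound 3 in this assay, so the three numbers cannot be told apart.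

Compound 4 `COc1ccc(-c2ccc(C)n2-c2ccc(-c3nc4ccc(F)cc4s3)cc2)cc1` differs from compound 3 by methoxy in place of methyl on an aromatic carbon. Within the data shown here, two measured steps bear on this change. The step of a 1.0-fold higher number from compound 1 to compound 2 (0.01 log units; within the scatter) replaces the same methyl group at the same aromatic carbon with a different group and leaves the number essentially unchanged. The step of a 1.2-fold lower number from compound 1 to compound 3 (0.07 log units; within the scatter) shows that a small change elsewhere on the shared core likewise stays within the scatter. Nothing in these three compounds points to a shift beyond the scatter for a methoxy in this place, so the step from compound 3 to compound 4 is expected to be a 1.0-fold higher number from compound 3 to compound 4 (0.01 log units; within the scatter). Compound 4 is therefore estimated at 2200 nM in this assay, with a range from 1000 nM to 4800 nM.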

Compound 4, concentration for 50% growth inhibition: 2120 nM
The estimate for compound 4 lay 1.0-fold (0.02 log units) above the measured number; measured number inside the range.
By their numbers in this assay, from the lowest: compounds 4, 3, 1 and 2 (each within the scatter of the next).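

In this assay, the step of a 1.0-fold lower number from compound 3 to compound 4 (0.01 log units; within the scatter) shows that this place on the 4-methylphenyl group also accepts an oxygen-linked group, with one more heavy atom and one hydrogen-bond acceptor, without a change beyond the scatter. The earlier replacement of methyl at this place was nitro on the core without fluoro, so the result extends the same flat reading to a second replacement and to the fluoro-bearing core. Nothing measured here accounts for this flatness or connects it to any property of the groups.

The compounds shown leave open whether an amine, a carboxylic acid or a longer chain such as butoxy at this place would give a step beyond the scatter. They also leave open whether any replacement here can move the number at all.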